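Compound 2 to compound 3: methyl gives way to methoxy

A few compounds are considered here, and "the series" means these few. Any claim that something is new, unique, unknown or untested is made for them only; others in the source may bear on it.

In a functional assay on HT-29 cells (Homo sapiens) for inhibition, read by sulforhodamine B assay, with a stated time of 48 h (a higher number here means a weaker inhibitor of growth, a lower number a stronger inhibitor of growth), compound 1 `CC(C)(C)NCc1c(C(=O)O)nn(-c2ccccc2)c1-c1ccc(F)cc1` gives > 680000 nM, which is a limit of the assay and not a number. Compound 2 `Cc1ccc(-c2c(CNC(C)(C)C)c(C(=O)O)nn2-c2ccccc2)cc1` gives > 688000 nM, and this too is a limit. Within the data shown here, compound 2 therefore has no number of its own, and the one other value that stands beside it is also only a limit.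

Compound 3 `COc1ccc(-c2c(CNC(C)(C)C)c(C(=O)O)nn2-c2ccccc2)cc1` differs from compound 2 at a single place: methoxy in place of methyl on an aromatic carbon. Methoxy stands in place of methyl on an aromatic carbon, and the rest of the structure is unchanged. Among the measured compounds shown here, the one measured step bearing on this change, at the same aromatic carbon, is a step that the two limits leave unreadable from compound 1 to compound 2, which offers no size to carry over, so no change beyond the scatter is expected in this assay and a further limit is the likeliest report. The expected step is an at least 1.0-fold lower number from compound 2 to compound 3 (0.01 log units; that floor lies within the scatter). Compound 3 is expected at 660000 nM, with an estimated range from 300000 nM to 750000 nM.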

Compound 3, concentration for 50% growth inhibition: > 659000 nM
Compound 3: only a limit was reported; the forecaster's own chance of this, stated with the estimate: 85%; the middle value is on the limit's open side.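

In this assay, among these compounds, compound 3 gives > 659000 nM, which is a limit of the assay and not a number, so no step among compound 1, compound 2 and compound 3 can be read. The compounds shown leave open whether fluoro, methyl and methoxy on this aromatic carbon differ at all in this assay, and what number any of the three would have.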